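Replacing a piperidine amide with an oxolanyl amide

A few compounds are considered here, and "the series" means these few. Any claim that something is new, unique, unknown or untested is made for them only; others in the source may bear on it.

Three compounds share a core that differs only in the group carried on the carbonyl carbon. Compound 1 `CCN(CC)S(=O)(=O)c1ccc(S(=O)(=O)N2CCC[C@@H](C(=O)N3CCC(O)CC3)C2)cc1` carries a hydroxypiperidine, compound 2 `CCN(CC)S(=O)(=O)c1ccc(S(=O)(=O)N2CCC[C@@H](C(=O)N3CCC(OC)CC3)C2)cc1` its methyl ether, and compound 3 `CCN(CC)S(=O)(=O)c1ccc(S(=O)(=O)N2CCC[C@@H](C(=O)N3CCC(COC)CC3)C2)cc1` a methoxymethylpiperidine. In a functional assay on MIA PaCa-2 cells (Homo sapiens) for inhibition, read by MTT assay, with a stated time of 3 days (on this read-out lower numbers stand for stronger inhibition and higher numbers for weaker inhibition), compound 1 gives only a limit, > 10000 nM. Compound 2 likewise reaches only a limit, > 10000 nM. Compound 3 also reaches only a limit, > 10000 nM. Every measured value therefore sits at the limit of > 10000 nM in this assay, at which 3 of the 3 values shown sit, so the steps a step that the two limits leave unreadable from compound 1 to compound 2, a step that the two limits leave unreadable from compound 1 to compound 3 and a step that the two limits leave unreadable from compound 2 to compound 3 cannot be read for size or direction. Compound 4 `CCN(CC)S(=O)(=O)c1ccc(S(=O)(=O)N2CCC[C@@H](C(=O)N[C@@H]3CCOC3)C2)cc1` is the next member, and it differs from compound 3 by the change ((oxolan-3-yl)amino in place of 4-(methoxymethyl)piperidin-1-yl on a carbonyl carbon). None of the measured steps gives a readable size, so nothing among these compounds points toward a gain in this assay. Compound 4 is expected to stay close to the same limit, with the step that the limit leaves unreadable from compound 3 to compound 4 carrying little weight. The estimate for compound 4 is 15000 nM, within a range from 3000 nM to 60000 nM.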

Compound 4, half-maximal inhibitory concentration: > 10000 nM
Compound 4 gave a limit, no number; the forecaster's own chance of this, stated with the estimate: 80%; the middle value lies beyond the limit too.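

Compound 4 also reaches only a limit (> 10000 nM). Its steps from compound 1, compound 2 and compound 3 therefore cannot be read for size or direction: the limit of > 10000 nM in this assay, at which 4 of the 4 values shown sit. The compounds shown leave open whether this assay can give a real number for any group on the carbonyl carbon.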